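A ring swap on the carbonyl of compound 3

The compounds below may be only part of what the source reports. "The series", "measured", "known", "first", "only" and "open" are said of these compounds alone.

In a functional assay on SK-MEL-28 cells (Homo sapiens) for cytotoxicity, read by MTT assay (a higher number here means a weaker inhibitor, a lower number a stronger inhibitor), three related compounds have been measured so far. Compound 1 (`O=S(=O)(NCCCNc1nccc(-c2c(-c3cccc(F)c3)nc3sccn23)n1)c1cccc(F)c1`) gives 8550 nM, compound 2 (`O=S(=O)(NCCCNc1nccc(-c2c(-c3cccc(F)c3)nc3sccn23)n1)c1ccc(Br)cc1`) gives 9400 nM, and compound 3 (`O=C(NCCNc1nccc(-c2c(-c3cccc(F)c3)nc3sccn23)n1)c1c(F)cccc1F`) gives 11400 nM. Compound 3 therefore stands level with the other two, inside the usual scatter of repeated measurements.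

The next compound, compound 4 (`O=C(NCCNc1nccc(-c2c(-c3cccc(F)c3)nc3sccn23)n1)c1ccc(C(F)(F)F)cc1`), differs from compound 3 in one group: 4-(trifluoromethyl)phenyl in place of 2,6-difluorophenyl on a carbonyl carbon. Put simply, 4-(trifluoromethyl)phenyl takes the place of 2,6-difluorophenyl on a carbonyl carbon.

Within the data shown here, no measured pair makes this exact swap. Among the measured compounds shown here, the closest precedent is the exchange of one substituted phenyl for another on a sulfonyl sulfur, a 1.1-fold higher number from compound 1 to compound 2 (0.04 log units; within the scatter), which stays within the scatter. Two broader changes exchange the sulfonyl-bearing portion for a carbonyl-bearing one, a 1.3-fold higher number from compound 1 to compound 3 (0.12 log units; within the scatter) and a 1.2-fold higher number from compound 2 to compound 3 (0.08 log units; within the scatter), and these also stay within the scatter. With so few compounds this is thin evidence, but no measured change has yet moved the number beyond the scatter, so no real shift is expected here.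

The estimated change is a 1.2-fold lower number from compound 3 to compound 4 (0.08 log units; within the scatter), which is expected to fall within the scatter. For compound 4 the expected value is 9500 nM, with an estimated range from 4000 nM to 22000 nM.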

Compound 4, half-maximal inhibitory concentration: 9260 nM
Beside the measured number, compound 4's estimate is 1.0-fold (0.01 log units) above it; the range from low to high includes it.
By their numbers in this assay, from the lowest: compounds 1, 4, 2 and 3 (each within the scatter of the next).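

In this assay, the first step measured on a carbonyl carbon is a 1.2-fold lower number from compound 3 to compound 4 (0.09 log units; within the scatter), so this exchange of one substituted phenyl for another leaves the number within the scatter. Among these compounds, the earlier steps changed the group on a sulfonyl sulfur or exchanged the whole sulfonyl-bearing portion, so this is the first direct look at the ring on the carbonyl itself. The entering 4-(trifluoromethyl)phenyl has 10 heavy atoms and the leaving 2,6-difluorophenyl has 8, and this difference in the fluorine-bearing groups comes with no shift that can be told from repeat-measurement noise, though nothing available bears on why the number holds level.

Both groups seen at this place are phenyl rings carrying fluorine, so this pair cannot show how far the carbonyl position tolerates other kinds of group. A phenyl ring carrying a carboxylic acid or an amine, or a saturated cyclohexyl ring on the same carbonyl carbon, could still move the number beyond the scatter, and the compounds shown give no hint either way.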